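The compounds below may be only part of what the source reports. "The series", "measured", "known", "first", "only" and "open" are said of these compounds alone.

Working notes, series of amides on the shared core.

Three compounds are in hand. Compound 1 `Cc1ccc(-c2nn(-c3ccc(F)cc3)cc2C(=O)Nc2ccc(C)c(S(=O)(=O)N3CCOCC3)c2)cc1` carries a 4-fluorophenyl on the aromatic nitrogen; in an assay on HEK-293T cells for inhibition of Bile acid receptor (Homo sapiens), read by a beta-lactamase reporter, with a stated time of 16 h (a lower number here means a stronger inhibitor, a higher number a weaker inhibitor), compound 1 gives 2490 nM. Compound 2 `Cc1ccc(-c2nn(C(C)C)cc2C(=O)Nc2ccc(C)c(S(=O)(=O)N3CCOCC3)c2)cc1` has isopropyl there, and in this assay compound 2 gives 1690 nM. Compound 3 `Cc1ccc(-c2nn(CC3CC3)cc2C(=O)Nc2ccc(C)c(S(=O)(=O)N3CCOCC3)c2)cc1` has cyclopropylmethyl, and in this assay compound 3 gives 849 nM. Compound 3 thus holds the lowest of the three numbers: a 2.9-fold lower number from compound 1 to compound 3 (0.47 log units; beyond the scatter), while a 2.0-fold lower number from compound 2 to compound 3 (0.30 log units; within the scatter) and a 1.5-fold lower number from compound 1 to compound 2 (0.17 log units; within the scatter).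

Compound 4 `Cc1ccc(-c2nn(CCCCO)cc2C(=O)Nc2ccc(C)c(S(=O)(=O)N3CCOCC3)c2)cc1` is not yet measured. It differs from compound 3 by 3-hydroxypropyl in place of cyclopropyl on a saturated chain carbon bound to an aromatic nitrogen. Going by the values given here, none of the measured steps introduces a hydrogen-bond donor or acceptor on the group at the aromatic nitrogen; the steps in hand only show that exchanging one hydrocarbon group for another moves this assay modestly at most. The nearest guide is a 2.0-fold lower number from compound 2 to compound 3 (0.30 log units; within the scatter), within the scatter. Compound 4 is therefore expected to sit near compound 3, with a wide range, estimated at 1300 nM (range 450 nM to 3800 nM), meaning an expected step of a 1.5-fold higher number from compound 3 to compound 4 (0.19 log units; within the scatter).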

Compound 4, half-maximal inhibitory concentration: 2610 nM
Estimate against measurement, compound 4: 2.0-fold (0.30 log units) below; low and high end bracket the measured number.
By their numbers in this assay, from the lowest: compounds 3, 2, 1 and 4 (each within the scatter of the next, the first and the last beyond it).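

In this assay, the change from cyclopropyl to 3-hydroxypropyl brings the first hydrogen-bond donor and acceptor to this position, and it gives a 3.1-fold higher number from compound 3 to compound 4 (0.49 log units; beyond the scatter). Against the other groups, a 1.5-fold higher number from compound 2 to compound 4 (0.19 log units; within the scatter) and a 1.0-fold higher number from compound 1 to compound 4 (0.02 log units; within the scatter), so 4-hydroxybutyl cannot be told apart from isopropyl or 4-fluorophenyl, and the gain seen with cyclopropylmethyl over 4-fluorophenyl does not carry over to this open chain. No measurement offered here accounts for the step.

The compounds shown do not separate the effect of adding the hydroxyl from that of losing the three-membered ring; a plain butyl chain would bear on that. Going by these compounds, how a methoxy, an amine or a carboxylic acid at the chain end would read also stays open.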